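Notes on compound 4: acetyl in place of methoxy

A few compounds are considered here, and "the series" means these few. Any claim that something is new, unique, unknown or untested is made for them only; others in the source may bear on it.

Measured in an ADME assay on the whole organism with Oryza sativa as the target, tested at 1 uM; a lower number here means a stronger effect, a higher number a weaker effect of the compound at the concentration tested:
compound 1 `Cc1ccccc1NC(=O)N[C@H](C)c1ccccc1` gives 100%
compound 2 `C[C@@H](NC(=O)Nc1ccccc1C(C)(C)C)c1ccccc1` gives 95%
compound 3 `COc1ccccc1NC(=O)N[C@H](C)c1ccccc1` gives 105%

The three compounds share one core and differ only in the group on one aromatic carbon. Compound 3, which carries the methoxy, sits within the scatter of compound 1 and of compound 2, so no order among the three can be drawn. The steps say the same: a number 5 percentage points lower from compound 1 to compound 2 (within the scatter), a number 5 percentage points higher from compound 1 to compound 3 (within the scatter), and a number 10 percentage points higher from compound 2 to compound 3 (within the scatter).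

Compound 4 is `CC(=O)c1ccccc1NC(=O)N[C@H](C)c1ccccc1`. Against compound 3 the difference is: acetyl in place of methoxy on an aromatic carbon.

Among the compounds with values here, the steps that bear on this are the three exchanges at the same aromatic carbon, methyl to tert-butyl, methyl to methoxy and tert-butyl to methoxy; each stayed within the scatter. Within the data shown here, none of them involved an acetyl, and no measured compound carries a group with a double bond outside aromatic rings at this place, so the change itself is untested. With every exchange at this carbon so far leaving the read-out unchanged beyond the scatter, compound 4 is expected to behave alike, with a number 5 percentage points lower from compound 3 to compound 4 (within the scatter). The estimate for compound 4 in this assay is 100%, ranging from 80% to 115%. The acetyl lies outside the groups tried, and the range is set wide.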

Compound 4, a percentage reported as activity, at one concentration (the size of the read-out at that concentration, not a potency): 95%
Estimate against measurement, compound 4: 5 percentage points above; low and high end bracket the measured number.
By their numbers in this assay, from the lowest: compounds 2, 4, 1 and 3 (each within the scatter of the next).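

In this assay, within the data shown here, the acetyl is the first group at this aromatic carbon, ortho to a large group, with a double bond outside aromatic rings, and it stays within the scatter of all three earlier groups (a number 10 percentage points lower from compound 3 to compound 4 (within the scatter); no change at the digits printed from compound 2 to compound 4 (within the scatter); a number 5 percentage points lower from compound 1 to compound 4 (within the scatter)). The series now holds four groups at this carbon, methyl, tert-butyl, methoxy and acetyl, that this read-out cannot tell apart, so adding a carbonyl here shows no effect that stands out from the scatter. Nothing available explains why the read-out stays flat at this place.

Still open, going by these compounds, is whether any group at this carbon can move the read-out beyond the scatter, for example an amine, a carboxylic acid, a longer chain or a chlorine atom. Also open is whether the same flat picture holds when the shared core changes somewhere else, as the compounds shown differ at this one carbon only.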